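Cytotoxicity notes: trifluoromethyl removal, compound 2 to compound 3

A few compounds are considered here, and "the series" means these few. Any claim that something is new, unique, unknown or untested is made for them only; others in the source may bear on it.

Measured compounds:
compound 1 `CCOC(=O)CCCCCOc1cccc(CN(C(=O)c2ccc(-c3cccc4ccccc34)cc2)C(C)C)c1`: > 26000 nM
compound 2 `CCOC(=O)CCCCCOc1cccc(CN(C(=O)c2ccc(-c3cc(C(F)(F)F)cc(C(F)(F)F)c3)cc2)C(C)C)c1`: > 26000 nM

Both results in an ADME assay on HEK293 cells (Homo sapiens) for cytotoxicity, read by CellTiter-Glo and resazurin assay, with a stated time of 72 h (a higher number here means that more compound is needed for the effect, a lower number that less compound is needed), are assay limits rather than numbers. Compound 1 reaches only the limit > 26000 nM. Compound 2 likewise sits at the limit > 26000 nM. Compound 2 therefore stands at the limit of > 26000 nM in this assay, at which 2 of the 2 values shown sit, and nothing in the numbers separates it from compound 1. Within the data shown here, no step between two measured compounds is available, so no measured size of change can be quoted for this series.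

Compound 3 `CCOC(=O)CCCCCOc1cccc(CN(C(=O)c2ccc(-c3cccc(C(F)(F)F)c3)cc2)C(C)C)c1` differs from compound 2 by hydrogen in place of trifluoromethyl on an aromatic carbon. With both measured values sitting at the limit, no direction of change can be read from the data for this kind of change. The expectation is that the step of a number no higher from compound 2 to compound 3 (the limit leaves the size open) is none beyond the scatter, with compound 3 most likely again reported only as a limit. Compound 3 is expected to give 26000 nM in this assay, within 13000 nM to 60000 nM.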

Compound 3, half-maximal effective concentration: > 26000 nM
Compound 3: only a limit was reported; the forecaster's own chance of this, stated with the estimate: 80%; the middle value lies on the limit itself.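

Compound 3 is reported only as a limit and not as a number, so no step from compound 1 or compound 2 to compound 3 can be read in this assay, and all three compounds stand together: the limit of > 26000 nM in this assay, at which 3 of the 3 values shown sit.

The compounds shown leave open whether hydrogen in place of trifluoromethyl on an aromatic carbon changes cytotoxicity at all, and which change to the shared core would give a measurable value.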